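Swapping an aryl amide for a pentyl amide

The source may hold more compounds than are shown below. What is called first, only, known or untested is meant among the compounds shown, and "the series" means these compounds.

Compound 1, `C=CC1=C(C(=O)NCc2ccccc2)C(c2ccc(OC)c(OC)c2)OC1`, in a functional assay on A549 cells (Homo sapiens) for cytotoxicity, read by MTT assay, with a stated time of 24 h; on this read-out higher numbers stand for weaker inhibition and lower numbers for stronger inhibition: > 100000 nM
Compound 2, `C=CC1=C(C(=O)Nc2ccc(OCC)cc2)C(c2ccc(OC)cc2)OC1`, in this assay: 17600 nM

Compound 1 reaches only (the limit of > 100000 nM in this assay, at which 1 of the 2 values shown sits), which is a limit of the assay and not a number. Among the measured compounds shown here, compound 2 therefore stands as the only numbered result in this assay, and no step between measured compounds can be drawn from these two.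

Compound 3, `C=CC1=C(C(=O)NCCCCC)C(c2ccc(OC)cc2)OC1`, is the next compound. Relative to compound 2 it carries pentyl in place of 4-ethoxyphenyl on an amide-type nitrogen; the ring-bound part and the shared core stay as they are. Nothing measured here shows what such a change does, so any step is an expectation rather than a reading. A step no larger than the usual scatter is expected, leaning toward weaker inhibition, which gives a 1.7-fold higher number from compound 2 to compound 3 (0.23 log units; within the scatter) as the estimated shift. For compound 3 the estimate in this assay is 30000 nM, with a range from 8000 nM to 100000 nM.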

Compound 3, half-maximal inhibitory concentration: 36500 nM
For compound 3 the middle estimate is 1.2-fold (0.09 log units) below the measured one, and the stated range covers the measured number.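

Among the compounds shown here, this is the first readable step at this amide-type nitrogen: in this assay, pentyl in place of 4-ethoxyphenyl gives a 2.1-fold higher number from compound 2 to compound 3 (0.32 log units; beyond the scatter). The step is modest, but it shows that the aromatic ring and its oxygen can be replaced by a chain of carbon only, with compound 3 still giving a numbered result, though with weaker inhibition than before the swap. Compound 1 remains a limit of the assay and not a number, so it cannot be placed on the same scale: the limit of > 100000 nM in this assay, at which 1 of the 3 values shown sits.

This single swap changes the ring, the oxygen and the chain length together, so it leaves open which of these accounts for the step. A butyl or octyl chain, a plain phenyl, or a chain ending in an amine would help separate these changes.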